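This account rests on a few compounds, and the source may have more. Where it says the series, first, only, none or still open, it means among the compounds named here.

Measured compounds:
compound 1 `C[C@H](C#Cc1cccc(C(=O)NCC[C@@H](c2ccc(F)cc2)c2ccc(C(F)(F)F)cc2)c1)N(O)C(N)=O` — 160 nM
compound 2 `CC(C#Cc1cccc(C(=O)NCCC(c2ccccc2)c2ccc(F)cc2)c1)N(O)C(N)=O` — 160 nM
compound 3 `C[C@H](C#Cc1cccc(C(=O)NCCC(c2ccc(F)cc2)c2ccc(OC(F)(F)F)cc2)c1)N(O)C(N)=O` — 260 nM

Of the compounds shown here, three that share one core have been measured in an assay for inhibition of Polyunsaturated fatty acid 5-lipoxygenase (Homo sapiens), read by HPLC, with stated times of 15 min and 10 min; on this read-out higher numbers stand for weaker inhibition and lower numbers for stronger inhibition. Compound 1 gives 160 nM, the same number at the digits shown as compound 2, which gives 160 nM; together they have the lowest numbers of the three. Compound 3 gives 260 nM, a somewhat higher number than compound 1, but the gap lies within the usual scatter of such measurements, so no order between these three can be stated.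

The step under consideration goes from compound 1 to compound 4 `C[C@H](C#Cc1cccc(C(=O)NCC[C@H](c2ccc(F)cc2)c2ccc(C(F)(F)F)cc2)c1)N(O)C(N)=O`. the two compounds have the same atoms and bonds and differ only in configuration as drawn: 1 of 2 stereo elements differ; a stereocentre at a saturated chain carbon is drawn R in compound 1 and S in compound 4 The saturated chain carbon that is drawn R in compound 1 is drawn S in compound 4; nothing else leaves or enters.

For the measured compounds named here, no step between two measured compounds touches this change. Compound 2, drawn without a configuration at this chain carbon, gives a number level with compound 1, which suggests that configuration at that carbon may not move the number far. The estimated step from compound 1 to compound 4 in this assay is therefore a 1.6-fold higher number from compound 1 to compound 4 (0.19 log units; within the scatter), a small shift toward a higher number that need not exceed the scatter. Compound 4 is expected to give about 250 nM, within a range of 100 nM to 700 nM.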

Compound 4, half-maximal inhibitory concentration: 230 nM
For compound 4 the middle estimate is 1.1-fold (0.04 log units) above the measured one; low and high end bracket the measured number.
By their numbers in this assay, from the lowest: compounds 1, 2, 4 and 3 (each within the scatter of the next).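

In this assay, reversing the configuration at the saturated chain carbon gives a 1.4-fold higher number from compound 1 to compound 4 (0.16 log units; within the scatter). For the compounds shown here, this is the first direct reading of this change, as no earlier pair of compounds isolated it, and the comparison concerns this stereocentre alone: the fact that compounds 1 and 4 differ only in the configuration as drawn. With the other groups of compound 1 in place, the configuration drawn at this carbon therefore moves the number by no more than the usual scatter of the measurements.

The compounds shown leave open whether this holds when another group, such as a carboxylic acid or an amine, stands in place of the trifluoromethyl group. They also leave open what the other stereo element, drawn the same in compound 1 and compound 4, contributes to the number.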